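Compound 2 and a trifluoromethyl swap

This account rests on a few compounds, and the source may have more. Where it says the series, first, only, none or still open, it means among the compounds named here.

In a functional assay on MDA-MB-231 cells (Homo sapiens) for antiproliferative activity, read by MTT assay, with a stated time of 24 h (a lower number here means a stronger inhibitor, a higher number a weaker inhibitor), compound 1 `O=C(O)CC(NS(=O)(=O)c1ccc(C(F)(F)F)cc1)c1ccccc1` gives 56100 nM. Compound 2 `CC(C)(C)c1ccc(C(CC(=O)O)NS(=O)(=O)c2ccc(F)cc2)cc1` gives 66200 nM, so the two values lie within the usual scatter of each other, and neither can be ranked. Compound 3 `CC(C)(C)c1ccc(C(CC(=O)O)NS(=O)(=O)c2ccc(C(F)(F)F)cc2)cc1` keeps the rest of compound 2 and changes one group: trifluoromethyl in place of fluoro on an aromatic carbon. Among the measured compounds shown here, no measured step isolates this change. The expectation rests on compound 1, which carries the entering group and gives 56100 nM, and on compound 2 at 66200 nM. A step no larger than the scatter is expected in this assay, with neither direction favoured. The expected change is a 1.2-fold lower number from compound 2 to compound 3 (0.08 log units; within the scatter). For compound 3 the estimated value is 55000 nM, with an expected range of 25000 nM to 100000 nM.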

Compound 3, half-maximal inhibitory concentration: 53700 nM
Compound 3: middle estimate off by 1.0-fold (0.01 log units), on the high side; measured number inside the range.
By their numbers in this assay, from the lowest: compounds 3, 1 and 2 (each within the scatter of the next).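

In this assay, trifluoromethyl in place of fluoro, para to a large group, gives a 1.2-fold lower number from compound 2 to compound 3 (0.09 log units; within the scatter), so with the tert-butyl held in place these two groups are not separated at this position. The other single change to compound 3, tert-butyl in place of hydrogen with trifluoromethyl held, gives a 1.0-fold lower number from compound 1 to compound 3 (0.02 log units; within the scatter), so that position does not separate its two groups here either. No measurement available bears on why these values sit so close together.

As far as these compounds go, whether an amine or a nitrile on this aromatic carbon would give a step beyond the scatter in this assay remains open. Also open, from the compounds shown here alone, is whether either change would behave the same way with a different group at the other site, since each change is seen only once.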